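A few compounds are considered here, and "the series" means these few. Any claim that something is new, unique, unknown or untested is made for them only; others in the source may bear on it.

Three compounds have been measured in a functional assay on Venous blood for antagonist activity at C-X-C chemokine receptor type 3 (Homo sapiens), read by flow cytometry, with a stated time of 30 min, in the presence of a further agent that is not named here; a higher number here means a weaker inhibitor, a lower number a stronger inhibitor:

compound 1 `Cc1nc(C)n(CC(=O)N2CCN(c3sc(C(F)(F)F)nc3-c3nc4ccc(C(C)(C)O)c(F)c4[nH]3)C[C@H]2C)n1`, 628 nM
compound 2 `Cc1nc(C)n(CC(=O)N2CCN(c3sc(C(F)(F)F)nc3-c3nc4ccc(OC5COC5)cc4[nH]3)C[C@H]2C)n1`, 1480 nM
compound 3 `C[C@@H]1CN(c2sc(C(F)(F)F)nc2-c2nc3ccccc3[nH]2)CCN1C(=O)Cn1cc(Cl)cn1`, 251 nM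

Among these three, compound 2 gives the highest number in this assay. The nearest of the other two is compound 1, whose number lies lower by a margin that is beyond the scatter; the furthest is compound 3, lower still and also beyond the scatter. None of the pairs differs in only one place, so no single change can be read off from the measured set.

Compound 4 `Cc1nc(C)n(CC(=O)N2CCN(c3sc(C(F)(F)F)nc3-c3nc4ccc(C5CCN(C)CC5)cc4[nH]3)C[C@H]2C)n1` has not yet been measured. It differs from compound 2 by one change: 1-methylpiperidin-4-yl in place of (oxetan-3-yl)oxy on an aromatic carbon. Among the measured compounds shown here, no measured pair shows the effect of this change, so the expectation rests only on where compound 2 stands, at the weak end of the three numbers.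

From compound 2 to compound 4 a step of a 2.1-fold lower number from compound 2 to compound 4 (0.33 log units; beyond the scatter) is expected, towards a lower number, though with a range wide enough to include no change beyond the scatter. For compound 4 the estimate in this assay is 700 nM, within a range from 200 nM to 2500 nM.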

Compound 4, half-maximal inhibitory concentration: 84.7 nM
Compound 4: the middle estimate sits 8.3-fold (0.92 log units) above what was measured; the measured number lies below the stated range.
By their numbers in this assay, from the lowest: compound 4; then compound 3; then compound 1; then compound 2.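

In this assay, the aromatic carbon meta to a fused ring and para to a fused ring proves sensitive to the group it carries: 1-methylpiperidin-4-yl in place of (oxetan-3-yl)oxy gives a 17-fold lower number from compound 2 to compound 4 (1.24 log units; beyond the scatter), a large step and the first effect of a single change that can be read in this series. The change alters several features at once, as 7 heavy atoms replace 5, a six-membered non-aromatic ring replaces a four-membered one, a ring nitrogen replaces both oxygens, and the linking oxygen is lost, so this one step cannot be assigned to any single feature. No supporting evidence is available to explain the size of the step.

The compounds shown leave open whether the ring nitrogen or its methyl group is needed, a question that piperidin-4-yl without the methyl group or tetrahydropyran-4-yl, with oxygen in place of the nitrogen, would address. They also leave open whether an open-chain amine such as dimethylaminomethyl at this carbon would give a comparable step.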